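The source may hold more compounds than are shown below. What is called first, only, known or untested is meant among the compounds shown, and "the series" means these compounds.

Compound 1 `O=C(NNc1ccccc1Cl)c1cccc(NS(=O)(=O)c2cnc(O)nc2O)c1` and compound 2 `O=C(NNc1cccc(Cl)c1)c1cccc(NS(=O)(=O)c2cnc(O)nc2O)c1` share one core, while compound 3 `O=C(NNc1ccccc1Cl)c1ccccc1NS(=O)(=O)c1cnc(O)nc1O` and compound 4 `O=C(NNc1cccc(Cl)c1)c1ccccc1NS(=O)(=O)c1cnc(O)nc1O` share a second one; the difference between the two cores is not broken down here. Within each pair the only change is the position of the chlorine on the phenyl ring that hangs from the amine nitrogen.

In a functional assay on SGC-7901 cells (Homo sapiens) for antiproliferative activity, read by MTT assay, with a stated time of 24 h (a lower number here means a stronger inhibitor, a higher number a weaker inhibitor), compound 1 gives 2270 nM. In this assay compound 2 gives 11800 nM. The change from compound 1 to compound 2 is 3-chlorophenyl in place of 2-chlorophenyl on an amine nitrogen, and it brought a 5.2-fold higher number from compound 1 to compound 2 (0.72 log units; beyond the scatter). For compound 3, this assay reports only a limit, > 20000 nM, so no number is known for it. That limit is described as the limit of > 20000 nM in this assay, at which 1 of the 3 values shown sits.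

Compound 4 differs from compound 3 by 3-chlorophenyl in place of 2-chlorophenyl on an amine nitrogen. Among the measured compounds shown here, this is the same change, at the same place, as the one from compound 1 to compound 2. Since compound 3 already sits at the limit, and the same change weakened compound 1 to compound 2 by a 5.2-fold higher number from compound 1 to compound 2 (0.72 log units; beyond the scatter), compound 4 is expected to be weaker again, with an estimated step that the limit leaves unreadable from compound 3 to compound 4. Compound 4 is therefore estimated at 60000 nM, most likely somewhere between 20000 nM and 200000 nM, and the assay is expected to report only a limit rather than a number.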

Compound 4, half-maximal inhibitory concentration: 10800 nM
For compound 4 the middle estimate is 5.6-fold (0.74 log units) above the measured one; measured number below the stated range.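

Setting 3-chlorophenyl in place of 2-chlorophenyl on the amine nitrogen gave, in this assay, an at least 1.8-fold lower number from compound 3 to compound 4 (0.26 log units; that floor lies within the scatter), so on this evidence the change does not carry from one core to the other with the same effect: the same change on two cores in this assay, a 5.2-fold higher number (0.72 log units; beyond the scatter) from compound 1 to compound 2 and an at least 1.8-fold lower number (0.26 log units; that floor lies within the scatter) from compound 3 to compound 4, at least 9.6-fold (0.98 log units) apart, beyond the scatter of two such steps

In this assay compound 3 has only a limit, > 20000 nM, and not a number.

As far as these compounds go, the true size of the step on this second core therefore stays unknown, and although its floor alone lies within the scatter, the gap between the two steps does not, so the two cores can be said to differ but not by exactly how much, and these two pairs do not show why.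

From the compounds shown here alone, both pairs carry only a chlorine on the phenyl ring, so it remains open whether a fluorine or a methyl group in its place would split the two cores in the same way. Going by these compounds, it also remains open what a plain phenyl without any chlorine would give on each core, which would show how much the chlorine itself matters in either place.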